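The compounds below may be only part of what the source reports. "The series", "measured", "known", "first", "only" and "open" are said of these compounds alone.

Measured compounds:
compound 1 `C[C@@H]1CN(C(=O)c2nc(Nc3cc(C4CC4)[nH]n3)c3cc(Cl)ccc3n2)CCN1C(=O)OC(C)(C)C`: 0.1%
compound 2 `CCCCCOC(=O)N1CCN(C(=O)c2nc(Nc3cc(C4CC4)[nH]n3)c3cc(Cl)ccc3n2)C[C@H]1C`: -3.8%
compound 3 `C[C@@H]1CN(C(=O)c2nc(Nc3cc(C4CC4)[nH]n3)c3cc(Cl)ccc3n2)CCN1C(=O)OCC(Cl)(Cl)Cl`: -1.5%

In an assay for inhibition of serine/threonine-protein kinase PAK 4 (Homo sapiens), read by FRET and Z'-LYTE, with a stated time of 60 min, tested at 0.5 uM, in the presence of a further agent that is not named here (on this read-out higher numbers stand for a stronger effect at the one concentration tested and lower numbers for a weaker effect), compound 3 gives -1.5%, which on the numbers shown sits between compound 1 and compound 2; its nearest neighbour is compound 1 with a number 1.6 percentage points lower from compound 1 to compound 3 (within the scatter), and the step of a number 2.3 percentage points higher from compound 2 to compound 3 (within the scatter) is the furthest of its two. All three values fall within the scatter of one another, so none of the three carbamate variants can be told apart on this read-out.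

Compound 4 `C[C@@H]1CN(C(=O)c2nc(Nc3cc(C4CC4)[nH]n3)c3cc(Cl)ccc3n2)CCN1C(=O)OCOC(=O)C(C)(C)C` is the next member. The change is ((tert-butyl)carbonyl)oxy in place of trichloromethyl on a saturated chain carbon bound to an oxygen next to a carbonyl group.

Among the measured compounds shown here, the steps that bear on it are the earlier exchanges at the same position: a number 3.9 percentage points lower from compound 1 to compound 2 (within the scatter), a number 1.6 percentage points lower from compound 1 to compound 3 (within the scatter) and a number 2.3 percentage points higher from compound 2 to compound 3 (within the scatter). Every one of them lies within the scatter, and the new group, though larger, is again an ester-type substituent on the same carbon. No step beyond the scatter is therefore expected, and the step of a number 0.5 percentage points higher from compound 3 to compound 4 (within the scatter) is estimated to be flat. Compound 4 is expected to give -1% in this assay, between -10% and 8%.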

Compound 4, a percentage reported as inhibition, at one concentration (the size of the read-out at that concentration, not a potency): 0.7%
Estimate against measurement, compound 4: 1.7 percentage points below; the measured number falls inside the stated range.
By their numbers in this assay, from the lowest: compounds 2, 3, 1 and 4 (each within the scatter of the next).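

In this assay, among the compounds shown here, ((tert-butyl)carbonyl)oxy is the first entering group at this place to bring a double bond outside aromatic rings and 2 hydrogen-bond acceptors, and it still gives a number 2.2 percentage points higher from compound 3 to compound 4 (within the scatter). The wider exchanges read the same way, with a number 4.5 percentage points higher from compound 2 to compound 4 (within the scatter) and a number 0.6 percentage points higher from compound 1 to compound 4 (within the scatter), so among compounds 1 to 4 this position has tolerated alkyl, trichloroalkyl and acyloxy-bearing groups without a step beyond the scatter. No measurement in hand accounts for this flat result.

Going by these compounds, with one concentration and all four compounds within the scatter of their neighbours, it stays open whether any group on this saturated chain carbon can move the read-out at all. A carboxylic acid or an amine at the end of a longer chain there would be a direct test.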